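Growing the Aromatic Substituent From Methyl to Ethyl

The source may report more compounds than this note shows. Statements on the series, on what has been measured and on what is new or still open speak of the compounds shown alone.

Measured compounds:
compound 1, `CCOC(=O)C1=C(N)Oc2ccc(C3CCCC3)cc2C1C(C#N)C(=O)OCC`, 3800 nM
compound 2, `CCOC(=O)C1=C(N)Oc2ccc(-c3ccc(C(C)(C)C)cc3)cc2C1C(C#N)C(=O)OCC`, 990 nM
compound 3, `CCOC(=O)C1=C(N)Oc2ccc(C)cc2C1C(C#N)C(=O)OCC`, 37000 nM

In a functional assay on Jurkat cells for inhibition of Apoptosis regulator Bcl-2 (Homo sapiens) (a lower number here means a stronger inhibitor of growth, a higher number a weaker inhibitor of growth), compound 3 stands highest of the three; the steps of a 9.7-fold higher number from compound 1 to compound 3 (0.99 log units; beyond the scatter) and a 37-fold higher number from compound 2 to compound 3 (1.57 log units; beyond the scatter) both end at it. Compound 4, `CCOC(=O)C1=C(N)Oc2ccc(CC)cc2C1C(C#N)C(=O)OCC`, differs from compound 3 by methyl in place of hydrogen on a saturated chain carbon bound to an aromatic carbon. Both measured steps that reach compound 3 replace a larger group with methyl and raise the number; the change to ethyl runs the other way but adds only one carbon, far less than cyclopentyl or 4-(tert-butyl)phenyl. A lower number is therefore expected, but a modest one, with a 1.9-fold lower number from compound 3 to compound 4 (0.27 log units; within the scatter) as the expected step. Compound 4 is estimated at 20000 nM, within the range 8000 nM to 50000 nM.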

Compound 4, concentration for 50% growth inhibition: 12000 nM
Estimate against measurement, compound 4: 1.7-fold (0.22 log units) above; low and high end bracket the measured number.
By their numbers in this assay, from the lowest: compound 2; then compound 1; then compound 4; then compound 3.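

In this assay, one added carbon on the aromatic substituent is already enough to register, with a 3.1-fold lower number from compound 3 to compound 4 (0.49 log units; beyond the scatter). Ethyl still falls short of the larger groups, with a 3.2-fold higher number from compound 1 to compound 4 (0.50 log units; beyond the scatter) and a 12-fold higher number from compound 2 to compound 4 (1.08 log units; beyond the scatter), so methyl, ethyl, cyclopentyl and 4-(tert-butyl)phenyl give steadily lower numbers across these four compounds, and none goes against that order. No evidence available here bears on the reason for this order.

As far as these compounds go, whether a propyl chain or an unsubstituted phenyl ring would fit the same order remains open. So does the effect of a group carrying oxygen or nitrogen, such as methoxy or an amine.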